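One aryl swap at the amide nitrogen, compound 3 to 4

The source may report more compounds than this note shows. Statements on the series, on what has been measured and on what is new or still open speak of the compounds shown alone.

Compound 1 `COc1cc(Cl)cc(-c2nn(-c3cccc(NC(=O)Nc4ccc(Cl)c(C(F)(F)F)c4)c3)cc2-c2ccncc2)c1`: in a functional assay on SNB-19 cells (Homo sapiens) for inhibition, read by sulforhodamine B assay, with a stated time of 48 h, tested at 1 uM (a higher number here means a weaker effect of the compound at the concentration tested, a lower number a stronger effect), compound 1 gives 87%.
Compound 2 `COc1cc(Cl)cc(-c2nn(-c3cccc(NC(=O)Nc4cc(C(F)(F)F)cc(C(F)(F)F)c4)c3)cc2-c2ccncc2)c1`: in this assay compound 2 gives 28%.
Compound 3 `COc1cc(Cl)cc(-c2nn(-c3cccc(NC(=O)Nc4ccc(Cl)c(Cl)c4)c3)cc2-c2ccncc2)c1`: in this assay compound 3 gives 89%.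

Compound 3 stands highest of the three numbers in this assay, meaning the weakest effect at the concentration tested. Its nearest neighbour is compound 1 (a number 2 percentage points higher from compound 1 to compound 3 (within the scatter)), and compound 2 lies far below it, beyond the scatter. Compound 4 `COc1cc(Cl)cc(-c2nn(-c3cccc(NC(=O)Nc4cccc(C(F)(F)F)c4)c3)cc2-c2ccncc2)c1` differs from compound 3 in one place: 3-(trifluoromethyl)phenyl in place of 3,4-dichlorophenyl on an amide-type nitrogen. Among the measured compounds shown here, the one measured step that bears on this change is a number 2 percentage points higher from compound 1 to compound 3 (within the scatter), which shows that exchanging chloro and trifluoromethyl on that ring moves the number little. For the measured compounds named here, no measured step covers the loss of the second substituent, so that part of the change is uncharted; compound 2, with a different pattern of two trifluoromethyl groups, shows only that a much lower number is possible on this ring. Compound 4 is therefore expected to stay near compound 3, with a number 9 percentage points lower from compound 3 to compound 4 (within the scatter) and a wider downside, giving an estimate of 80% in this assay with a range from 50% to 100%.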

Compound 4, a percentage reported as activity, at one concentration (the size of the read-out at that concentration, not a potency): 77%
Compound 4: middle estimate off by 3 percentage points, on the high side; the measured number falls inside the stated range.
By their numbers in this assay, from the lowest: compound 2; then compounds 4, 1 and 3 (each within the scatter of the next, the first and the last beyond it).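

In this assay, the aryl group on the amide-type nitrogen now shows a graded response. Hydrogen in place of chloro gives a number 10 percentage points lower from compound 1 to compound 4 (within the scatter), while the full swap from 3,4-dichlorophenyl to 3-(trifluoromethyl)phenyl gives a number 12 percentage points lower from compound 3 to compound 4 (beyond the scatter). Hydrogen in place of one of the two trifluoromethyl groups gives a number 49 percentage points higher from compound 2 to compound 4 (beyond the scatter), so a single trifluoromethyl group does not reproduce the low number of compound 2, and nothing measured here explains these differences.

From the compounds shown here alone, it remains open whether that low number needs trifluoromethyl itself or only two substituents placed as in compound 2. Two chloro groups in that pattern, or a nitrile or a tert-butyl group in place of trifluoromethyl, would separate these readings.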